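Swapping the propargyl amide of compound 2 for cyclopropyl

The source may report more compounds than this note shows. Statements on the series, on what has been measured and on what is new or still open speak of the compounds shown alone.

Measured compounds:
- Compound 1 `COc1ccc(/C(C)=C(/C)C(=O)NC2CC2)cc1`: 300 mg/kg
- Compound 2 `C#CCNC(=O)/C(C)=C(\C)c1ccc(Br)cc1`: 150 mg/kg
- Compound 3 `C=CCNC(=O)/C(C)=C(\C)c1cc(OC)c(OC)c(OC)c1`: 190 mg/kg

In a toxicity assay on the whole organism (strain Icem-CET (SPF Caw)) for cytotoxicity, with Mus musculus as the target (a higher number here means that more compound is needed for the effect, a lower number that less compound is needed), compound 2 gives 150 mg/kg, the lowest of the three numbers shown. Its nearest neighbour is compound 3 with 190 mg/kg, and the furthest is compound 1 with 300 mg/kg; both gaps fall within the usual scatter of this assay, so the three compounds cannot be separated on these numbers.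

Compound 4 `C/C(C(=O)NC1CC1)=C(/C)c1ccc(Br)cc1` has not been measured. It differs from compound 2 in one place: cyclopropyl in place of propargyl on an amide-type nitrogen. Going by the values given here, no pair of measured compounds isolates this exchange, since compound 1, the only other cyclopropyl amide, also carries a different substituted ring. The account therefore expects no step beyond the scatter, at most a mild move toward a higher number; the expected step is a 1.4-fold higher number from compound 2 to compound 4 (0.15 log units; within the scatter). Compound 4 is estimated at 210 mg/kg, with a range from 110 mg/kg to 400 mg/kg.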

Compound 4, dose for half-maximal effect: 130 mg/kg
Estimate against measurement, compound 4: 1.6-fold (0.21 log units) above, and the stated range covers the measured number.
By their numbers in this assay, from the lowest: compounds 4, 2, 3 and 1 (each within the scatter of the next, the first and the last beyond it).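

Going by these compounds alone, the exchange of propargyl for cyclopropyl on the amide-type nitrogen is now isolated in this assay and gives a 1.2-fold lower number from compound 2 to compound 4 (0.06 log units; within the scatter) as its step, which the earlier compounds, differing in more than one place, could not show. On this core, then, this position accepts a three-membered non-aromatic ring of carbon in place of a chain with a triple bond without the two compounds being separated in this assay. Nothing available explains why the two groups read alike.

On these data alone, whether a longer chain, a phenyl group or a carboxylic acid on this nitrogen would move the number beyond the scatter remains open. Also open, as far as these compounds go, is whether the same exchange would read alike on the core of compound 3, which carries a different substituted ring.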